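A few compounds are considered here, and "the series" means these few. Any claim that something is new, unique, unknown or untested is made for them only; others in the source may bear on it.

Compound 1 is `CC(C)N(Cc1cccc(OCCCCCC(=O)O)c1)C(=O)c1ccccc1`. In an ADME assay on HEK293 cells (Homo sapiens) for cytotoxicity, read by CellTiter-Glo and resazurin assay, with a stated time of 72 h (on this read-out higher numbers stand for an effect only at larger amounts of compound and lower numbers for an effect already at smaller amounts), compound 1 gives > 26000 nM, which is a limit of the assay rather than a number.
Compound 2 is `CC(C)N(Cc1cccc(OCCCCCC(=O)O)c1)C(=O)c1ccc(-c2cccc(S(C)(=O)=O)c2)cc1`. In this assay compound 2 gives > 26000 nM, again a limit.
Compound 3 is `CCOC(=O)CCCCCOc1cccc(CN(C(=O)c2ccccc2)C(C)C)c1`. In this assay compound 3 gives > 26000 nM, also a limit.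

Compound 3 thus stands at the same limit as the other two compounds: all three values shown sit there (the limit of > 26000 nM in this assay, at which 3 of the 3 values shown sit), and no ordering among them can be read. Compound 4 is `CCOC(=O)CCCCCOc1cccc(CN(C(=O)c2ccc(-c3ccc4ccccc4c3)cc2)C(C)C)c1`; it differs from compound 3 by naphthalen-2-yl in place of hydrogen on an aromatic carbon, on an aromatic carbon that is para to a large group.

Within the data shown here, two measured steps bear on this change. The step from compound 1 to compound 2, a step that the two limits leave unreadable from compound 1 to compound 2, also adds an aryl group on an aromatic carbon of the same core, and the step from compound 1 to compound 3, a step that the two limits leave unreadable from compound 1 to compound 3, installs the ethyl ester that compound 4 shares with compound 3. Both steps are unreadable because both ends are limits. The expectation is therefore no step beyond the scatter in this assay, so that compound 4 is expected to remain at the limit, giving an estimated step that the limit leaves unreadable from compound 3 to compound 4. For compound 4 the estimated value is 30000 nM, expected to fall between 10000 nM and 100000 nM.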

Compound 4, half-maximal effective concentration: > 26000 nM
Compound 4 ended at the assay's limit; the forecaster's own chance of this, stated with the estimate: 85%; the middle value lies beyond the limit too.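

The step between compound 3 and compound 4 cannot be read, since both values in this assay are limits and not numbers: the limit of > 26000 nM in this assay, at which 4 of the 4 values shown sit.

The compounds shown leave open at what amount of compound any of them would have an effect in this assay, and whether any change to the shared core would alter it.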